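A few compounds are considered here, and "the series" means these few. Any claim that something is new, unique, unknown or untested is made for them only; others in the source may bear on it.

Working notes on the series: in a functional assay on A549 cells (Homo sapiens) for cytotoxicity, read by MTT assay, with a stated time of 72 h (a lower number here means a stronger inhibitor, a higher number a weaker inhibitor), compound 1 (`O=C(/C=C/c1cccc(Cl)c1Cl)Nc1cc2c(Nc3ccc(F)c(Cl)c3)ncnc2cc1O[C@H]1CCOC1`) gives 23200 nM, and compound 2 (`N#Cc1ccc(/C=C/C(=O)Nc2cc3c(Nc4ccc(F)c(Cl)c4)ncnc3cc2O[C@H]2CCOC2)cc1`) is reported as "not active" (no number reported), with no number. Compound 3 (`COc1ccc(/C=C/C(=O)Nc2cc3c(Nc4ccc(F)c(Cl)c4)ncnc3cc2O[C@H]2CCOC2)c(OC)c1OC`) gives 70 nM, the lower of the two numbers. The next entry is compound 4 (`O=C(/C=C/c1ccc(F)cc1Cl)Nc1cc2c(Nc3ccc(F)c(Cl)c3)ncnc2cc1O[C@H]1CCOC1`), with the change (2-chloro-4-fluorophenyl in place of 2,3,4-trimethoxyphenyl on a double-bonded chain carbon bound to a double-bonded chain carbon). For the measured compounds named here, one measured step bears on this: a 330-fold lower number from compound 1 to compound 3 (2.52 log units; beyond the scatter), where 2,3,4-trimethoxyphenyl took the place of 2,3-dichlorophenyl. Compound 4 gives up that same 2,3,4-trimethoxyphenyl for 2-chloro-4-fluorophenyl, so a large step to a higher number is expected in this assay, though a single step is thin support. The expected size is a 130-fold higher number from compound 3 to compound 4 (2.11 log units; beyond the scatter). Compound 4 is estimated at 9000 nM, with an expected range of 1200 nM to 40000 nM.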

Compound 4, half-maximal inhibitory concentration: 5190 nM
For compound 4 the middle estimate is 1.7-fold (0.24 log units) above the measured one, within the range that was stated.
By their numbers in this assay, from the lowest: compound 3; then compound 4; then compound 1.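

In this assay, 2-chloro-4-fluorophenyl in place of 2,3,4-trimethoxyphenyl gives a 74-fold higher number from compound 3 to compound 4 (1.87 log units; beyond the scatter) on the double-bonded chain carbon, so the low number of compound 3 is not kept by this other substituted phenyl. The two chlorinated phenyl groups also differ, with a 4.5-fold lower number from compound 1 to compound 4 (0.65 log units; beyond the scatter) as a modest step, so this place still separates halogen-bearing groups. No supporting data explain either step.

Open, on these data alone, is whether compound 3 needs all its methoxy groups, and how a phenyl bearing one methoxy or a dimethylamino group would read here.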